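A few compounds are considered here, and "the series" means these few. Any claim that something is new, unique, unknown or untested is made for them only; others in the source may bear on it.

The measured compounds in a functional assay on C6 cells (Rattus norvegicus) for cytotoxicity, read by MTT assay, with a stated time of 24 h, tested at 6 ug/mL; on this read-out lower numbers stand for a stronger effect and higher numbers for a weaker effect at the one concentration tested:
Compound 1 `Cc1ccc(-c2cs/c(=N/NC(=O)CSc3nnnn3C)n2-c2ccccc2)cc1` gives 88%
Compound 2 `Cn1nnnc1SCC(=O)N/N=c1/scc(-c2ccc(C#N)cc2)n1-c1ccccc1` gives 63.5%

Compound 2 stands at the lower of the two numbers in this assay, and its nearest neighbour is compound 1, which sits higher by a number 24.5 percentage points lower from compound 1 to compound 2 (beyond the scatter). Compound 3 `Cn1nnnc1SCC(=O)N/N=c1/scc(-c2ccc([N+](=O)[O-])cc2)n1-c1ccccc1` differs from compound 2 in a single place: nitro in place of cyano on an aromatic carbon. Going by the values given here, no measured step bears directly on this change. Among the compounds with values here, the only step seen, a number 24.5 percentage points lower from compound 1 to compound 2 (beyond the scatter), concerns a different pair of groups at the same aromatic carbon and shows merely that a change at that place can move the number beyond the scatter. Whether a nitro group behaves like a cyano group cannot be read from two compounds. Compound 3 is therefore expected to stay close to compound 2, with a number 3.5 percentage points lower from compound 2 to compound 3 (within the scatter) as the expected step, not beyond the scatter. Compound 3 is estimated at 60%, in a range from 40% to 85%.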

Compound 3, a percentage reported as activity, at one concentration (the size of the read-out at that concentration, not a potency): 80.4%
Beside the measured number, compound 3's estimate is 20.4 percentage points below it, and the stated range covers the measured number.
By their numbers in this assay, from the lowest: compound 2; then compounds 3 and 1 (each within the scatter of the next).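

In this assay the change from 4-cyanophenyl to 4-nitrophenyl gives a number 16.9 percentage points higher from compound 2 to compound 3 (beyond the scatter), so on this aromatic carbon, para to a large group, nitro and cyano cannot be treated as interchangeable. Nitro in place of methyl gives a number 7.6 percentage points lower from compound 1 to compound 3 (within the scatter), which leaves compound 2 as the only one of the three set apart by steps beyond the scatter from both others, so what the first step showed for this position now reads as a result tied to cyano, not as a general response to replacing methyl. Nothing measured here gives a reason for this difference.

Going by these compounds, it remains open whether any other group at this carbon, such as an amine, a carboxylic acid or a methoxy group, would join cyano or stay with nitro and methyl. Also open, on these data alone, is whether the gap between cyano and nitro would persist with a change elsewhere on the shared core.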